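Swapping a bromomethyl ketone for an epoxide on a stable core

The source may hold more compounds than are shown below. What is called first, only, known or untested is meant among the compounds shown, and "the series" means these compounds.

Compound 3 `O=C(CBr)c1cc(C(F)(F)F)cc(C(F)(F)F)c1` carries a (bromomethyl)carbonyl group on the shared core. In an ADME assay for pharmacokinetics, read by HPLC, in phosphate buffer, with a stated time of 72 h, at pH 7.4, tested at 250 uM (on this read-out lower numbers stand for a shorter-lived compound and higher numbers for a longer-lived compound), compound 3 gives < 0.017 h, which is a limit of the assay rather than a measured number. Compound 1 `C=CS(=O)(=O)c1cc(C(F)(F)F)cc(C(F)(F)F)c1` sits at the same limit, giving < 0.017 h in this assay. Compound 2 `N#Cc1cc(C(F)(F)F)cc(C(F)(F)F)c1`, the nitrile, reaches the opposite limit, giving > 50 h in this assay. So compound 3 stands at the short-lived end, at the limit of < 0.017 h in this assay, at which 2 of the 3 values shown sit, while the long-lived end is defined by the limit of > 50 h in this assay, at which 1 of the 3 values shown sits.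

Compound 4 `FC(F)(F)c1cc(C2CO2)cc(C(F)(F)F)c1` differs from compound 3 in one place: oxiran-2-yl in place of (bromomethyl)carbonyl on an aromatic carbon. Among the compounds with values here, two measured steps bear on this. The step that the two limits leave unreadable from compound 1 to compound 3 cannot be read, as both compounds sit at a limit. The step of an at least 2900-fold lower number from compound 2 to compound 3 (3.46 log units; beyond the scatter) shows that replacing the nitrile with the (bromomethyl)carbonyl group moves the number by a large amount downward, so removing that group can move it back upward by a large amount. Within the data shown here, the epoxide is itself a different group, and no measured compound carries one, so the size remains uncertain.

On that basis compound 4 is expected to show a large rise, an at least 2300-fold higher number from compound 3 to compound 4 (3.37 log units; beyond the scatter), in this assay. The estimated half-life of compound 4 is 40 h, within a range from 4 h to 200 h.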

Compound 4, half-life: > 50 h
Compound 4 ended at the assay's limit; the forecaster's own chance of this, stated with the estimate: 45%; middle value at least 1.2-fold (0.09 log units) away from the limit.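

In this assay, oxiran-2-yl on this aromatic carbon gives an at least 2900-fold higher number from compound 3 to compound 4 (3.46 log units; beyond the scatter), and the same change measured against the vinylsulfonyl group gives an at least 2900-fold higher number from compound 1 to compound 4 (3.46 log units; beyond the scatter). Until now, the nitrile of compound 2 was the only group shown on the shared core at the long-lived end, so compound 4 shows that a three-membered ring containing oxygen can also sit at this place without the compound falling to the short-lived end. The value of compound 4 is a limit of the assay and not a measured number, and it adds a second compound to that end of the read-out: the limit of > 50 h in this assay, at which 2 of the 4 values shown sit.

The step between compound 2 and compound 4 cannot be read, so the compounds shown do not tell how long compound 4 lasts compared with the nitrile, or how far its half-life extends past the limit. Every value shown in this assay is a limit, which leaves open whether an amine, a carboxylic acid or a longer carbon chain at this place would give a half-life that could be read as an actual number.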